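Phenyl in Place of Ethyl: What to Expect of Compound 4

This account rests on a few compounds, and the source may have more. Where it says the series, first, only, none or still open, it means among the compounds named here.

Measured so far, in a functional assay on HT-29 cells (Homo sapiens) for cytotoxicity, read by MTT assay, with a stated time of 72 h; on this read-out higher numbers stand for weaker inhibition of growth and lower numbers for stronger inhibition of growth:
Compound 1, `COc1ccc(OC(=O)Nc2ccc([Se]C#N)cc2)cc1`: compound 1 gives 13600 nM
Compound 2, `CCCOC(=O)Nc1ccc([Se]C#N)cc1`: compound 2 gives 28400 nM
Compound 3, `Cc1ccc(OC(=O)Nc2ccc([Se]C#N)cc2)cc1`: compound 3 gives 8800 nM

Compound 2 stands at the highest of the three numbers in this assay; compound 1 lies a gap beyond the scatter below it, and compound 3 lies further below, also beyond the scatter. Compound 4, `N#C[Se]c1ccc(NC(=O)OCc2ccccc2)cc1`, differs from compound 2 in one place: phenyl in place of ethyl on a saturated chain carbon bound to an oxygen next to a carbonyl group. Among the compounds with values here, the only measured step between close neighbours, a 1.5-fold lower number from compound 1 to compound 3 (0.19 log units; within the scatter), concerns a swap on an aromatic carbon and lies within the scatter, so it says little about replacing ethyl with phenyl. What the values do show is that compound 2, whose chain end carries no ring, gives the highest number, while compound 1 and compound 3, whose chain ends each carry a six-membered aromatic ring, give lower numbers. Compound 4 also brings a six-membered aromatic ring to its chain end, so a somewhat lower number is expected. With so little direct support, the step of a 1.9-fold lower number from compound 2 to compound 4 (0.28 log units; within the scatter) is estimated to be modest. Compound 4 is expected to give about 15000 nM in this assay, within a range of 7000 nM to 35000 nM.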

Compound 4, concentration for 50% growth inhibition: 13300 nM
Estimate against measurement, compound 4: 1.1-fold (0.05 log units) above; the range from low to high includes it.
By their numbers in this assay, from the lowest: compounds 3, 4 and 1 (each within the scatter of the next); then compound 2.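

Phenyl in place of ethyl on a saturated chain carbon bound to an oxygen next to a carbonyl group produces a 2.1-fold lower number from compound 2 to compound 4 (0.33 log units; beyond the scatter) in this assay and so gives the first measured change between close neighbours that clears the usual scatter. Within the data shown here, the one earlier step concerned an aromatic carbon and stayed within the scatter, so this is the first sign that this place can shift the read-out, here with a six-membered aromatic ring entering and a group without a ring leaving, although the shift is modest and rests on a single pair. Nothing measured here explains the shift, and its cause stays unknown.

Compound 2 and compound 4 alone cannot say whether the aromatic ring itself matters or simply the greater number of carbons, a question that cyclohexyl or a longer chain at this place would help to settle. They also leave open how the number would respond to an amine or a carboxylic acid on the new phenyl ring, and whether the same swap would hold in another cell line.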